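This account rests on a few compounds, and the source may have more. Where it says the series, first, only, none or still open, it means among the compounds named here.

Compounds 1 and 2 share one core and differ only in the aromatic group carried on a saturated chain carbon, two bonds along the chain from an oxygen on an aromatic ring. Compound 1 `Cc1nc(C)c([C@H](OC(C)(C)C)C(=O)O)c(N2CCC(C)(C)CC2)c1-c1ccc(OCCc2ccccn2)cc1` bears a pyridin-2-yl there, compound 2 `Cc1nc(CCOc2ccc(-c3c(C)nc(C)c([C@H](OC(C)(C)C)C(=O)O)c3N3CCC(C)(C)CC3)cc2)cs1` a 2-methyl-1,3-thiazol-4-yl. In an ADME assay on microsomes from liver (Homo sapiens) for metabolic stability, read by LC-MS, tested at 0.5 uM (a higher number here means that the compound lasts longer, a lower number that the compound disappears faster), compound 2 gives 0.683 h, and compound 1 gives 0.5 h; the step of a 1.4-fold higher number from compound 1 to compound 2 (0.14 log units; within the scatter) is within the scatter, so the two stand level on half-life. Compound 3 `Cc1nc(C)c(CCOc2ccc(-c3c(C)nc(C)c([C@H](OC(C)(C)C)C(=O)O)c3N3CCC(C)(C)CC3)cc2)s1` follows from compound 2 through the change (2,4-dimethyl-1,3-thiazol-5-yl in place of 2-methyl-1,3-thiazol-4-yl on a saturated chain carbon, two bonds along the chain from an oxygen on an aromatic ring). Within the data shown here, the only measured step at this position, a 1.4-fold higher number from compound 1 to compound 2 (0.14 log units; within the scatter), stayed within the scatter, and nothing among the measured compounds points to a larger effect from a second thiazole variant. On that basis the expected step is a 1.0-fold lower number from compound 2 to compound 3 (0.00 log units; within the scatter), none beyond the scatter. Compound 3 is therefore estimated at 0.68 h in this assay, with a range of 0.35 h to 1.3 h.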

Compound 3, half-life: 0.917 h
For compound 3 the middle estimate is 1.3-fold (0.13 log units) below the measured one; low and high end bracket the measured number.
By their numbers in this assay, from the lowest: compounds 1, 2 and 3 (each within the scatter of the next).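

In this assay, the 2,4-dimethyl-1,3-thiazol-5-yl in place of the 2-methyl-1,3-thiazol-4-yl gives a step that stays within the scatter (a 1.3-fold higher number from compound 2 to compound 3 (0.13 log units; within the scatter)), so the two thiazole groups stand level on half-life. In place of the pyridin-2-yl, the same group also stays within the scatter (a 1.8-fold higher number from compound 1 to compound 3 (0.26 log units; within the scatter)), so the three aromatic groups tested on a saturated chain carbon, two bonds along the chain from an oxygen on an aromatic ring, do not separate on this read-out. Nothing available here accounts for how closely these groups sit.

From the compounds shown here alone, it remains open whether an amine, a carboxylic acid or a saturated ring in place of the aromatic group, or a longer chain carrying it, would give a step beyond the scatter. All three compounds share one core, so they also leave open whether these steps would hold on a different core.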